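The compounds below may be only part of what the source reports. "The series", "measured", "known", "first", "only" and "open" are said of these compounds alone.

Compound 1 `CCCCCCOC(=O)C(CCCCN1C(=O)CCC1=O)N1CCCCC1=O`: > 6250 nM. Compound 2 `CCCCCCCOC(=O)C(CCCCN1C(=O)CCC1=O)N1CCCCC1=O`: > 6250 nM.

In an ADME assay on SK-N-MC cells (Homo sapiens) for antiproliferative activity, read by MTT assay, with a stated time of 72 h (on this read-out higher numbers stand for weaker inhibition and lower numbers for stronger inhibition), compound 1 reaches only a limit of the assay, > 6250 nM. In this assay compound 2 likewise gives only a limit, > 6250 nM. The step that the two limits leave unreadable from compound 1 to compound 2 is thus unreadable, as the two limits show (the limit of > 6250 nM in this assay, at which 2 of the 2 values shown sit). Compound 3 `CCCCCCCCOC(=O)C(CCCCN1C(=O)CCC1=O)N1CCCCC1=O` differs from compound 2 by methyl in place of hydrogen on a saturated chain carbon, seven bonds along the chain from an oxygen next to a carbonyl group. Among the measured compounds shown here, the only measured step bearing on this change is that unreadable one, so no direction beyond the scatter can be expected in this assay. Compound 3 is therefore estimated at 10000 nM, with a range from 4000 nM to 40000 nM. The expected step is a step that the limit leaves unreadable from compound 2 to compound 3, and the result will most likely again be reported only as a limit.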

Compound 3, half-maximal inhibitory concentration: > 6250 nM
Compound 3 ended at the assay's limit; the forecaster's own chance of this, stated with the estimate: 80%; the middle value is on the limit's open side.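

Compound 3, like compound 1 and compound 2, gives only a limit in this assay, so no step among these compounds can be read. The compounds shown leave open what actual value any of them has and whether the added methyl changes it.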